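Benzamidomethyl in place of 4-methylphenyl: working notes

A few compounds are considered here, and "the series" means these few. Any claim that something is new, unique, unknown or untested is made for them only; others in the source may bear on it.

In a functional assay on A-431 cells (Homo sapiens) for inhibition, read by MTT assay, with a stated time of 72 h (a higher number here means a weaker inhibitor, a lower number a stronger inhibitor), compound 1 (`Cc1ccc(-c2nnc(SCCCN3CCN(c4nc5ccccc5o4)CC3)o2)cc1`) gives 100000 nM and compound 2 (`Brc1ccc(-c2nnc(SCCCN3CCN(c4nc5ccccc5o4)CC3)o2)cc1`) gives 57800 nM in the same read-out. Bromo in place of methyl on an aromatic carbon gives a 1.7-fold lower number from compound 1 to compound 2 (0.24 log units; within the scatter) in this pair. Compound 3 (`Cc1ccc(-c2nnc(SCCCN3CCN(c4nc5ccccc5s4)CC3)o2)cc1`) stands at 61600 nM in this small set. For the measured compounds named here, its benzothiazolyl exchange, 1,3-benzothiazol-2-yl in place of 1,3-benzoxazol-2-yl on an amine nitrogen in a ring, gives a 1.6-fold lower number from compound 1 to compound 3 (0.21 log units; within the scatter) as the only measured step to compound 3. The values of compound 2 and compound 3 lie within the scatter of each other.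

Compound 4 (`O=C(NCc1nnc(SCCCN2CCN(c3nc4ccccc4s3)CC2)o1)c1ccccc1`) has benzamidomethyl in place of 4-methylphenyl on an aromatic carbon, counted as benzamidomethyl in place of 4-methylphenyl on an aromatic carbon for this change. Going by the values given here, no measured step replaces the whole 4-methylphenyl group, so the two steps above are only a loose guide, and both stay within the scatter. A step of a 1.2-fold lower number from compound 3 to compound 4 (0.09 log units; within the scatter) is expected in this assay with no change beyond the scatter. Compound 4 is estimated at 50000 nM with an expected range from 15000 nM to 120000 nM for now.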

Compound 4, half-maximal inhibitory concentration: 55900 nM
Estimate against measurement, compound 4: 1.1-fold (0.05 log units) below, and the stated range covers the measured number.
By their numbers in this assay, from the lowest: compounds 4, 2, 3 and 1 (each within the scatter of the next).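

In this assay, replacing the whole 4-methylphenyl group with benzamidomethyl on the five-membered aromatic ring gives a 1.1-fold lower number from compound 3 to compound 4 (0.04 log units; within the scatter). The earlier steps shown here changed only a substituent on the aromatic ring or the group on the ring amine nitrogen, whereas this step shows that the position accepts a larger group carrying a hydrogen-bond donor and a hydrogen-bond acceptor with no change beyond the scatter. No measurement shown here accounts for this result.

The compounds shown leave open whether a basic amine or a carboxylic acid in place of the benzamide phenyl ring, or a longer chain in place of the methylene, would move the number beyond the scatter. As far as these compounds go, it also remains open whether benzamidomethyl gives the same result with 1,3-benzoxazol-2-yl on the ring amine nitrogen.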